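Amide aryl swap on the triazole side chain

The source may hold more compounds than are shown below. What is called first, only, known or untested is meant among the compounds shown, and "the series" means these compounds.

In a functional assay on A549 cells (Homo sapiens) for inhibition, read by MTT assay, with a stated time of 24 h (a lower number here means a stronger inhibitor, a higher number a weaker inhibitor), compound 1 `CCOC(=O)C1=Cc2ccccc2OC1(OCc1cn(-c2ccc(F)cc2)nn1)C(F)(F)F` gives 7300 nM. Compound 2 `CCOC(=O)C1=Cc2ccccc2OC1(OCc1cn(CC(=O)Nc2ccccc2Br)nn1)C(F)(F)F` carries ((2-bromophenyl)carbamoyl)methyl in place of 4-fluorophenyl on an aromatic nitrogen. In this assay compound 2 reaches only a limit, > 150000 nM. The step of an at least 20-fold higher number from compound 1 to compound 2 (1.31 log units; beyond the scatter) is thus known only as a bound, resting on (the limit of > 150000 nM in this assay, at which 1 of the 2 values shown sits). Compound 3 `CCOC(=O)C1=Cc2ccccc2OC1(OCc1cn(CC(=O)Nc2ccc(I)cc2Cl)nn1)C(F)(F)F` differs from compound 2 by 2-chloro-4-iodophenyl in place of 2-bromophenyl on an amide-type nitrogen, the amide-type nitrogen and the rest of the side chain being unchanged. Going by the values given here, no measured step bears on this change directly; the single measured step, an at least 20-fold higher number from compound 1 to compound 2 (1.31 log units; beyond the scatter), concerns another position and leaves compound 2 at the limit. For compound 3 no step beyond the scatter is expected, so a value at or past the same limit is the likely outcome. Compound 3 is estimated at 200000 nM (range 60000 nM to 600000 nM). The expected step is a step that the limit leaves unreadable from compound 2 to compound 3, and a limit rather than a number is the more probable readout.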

Compound 3, half-maximal inhibitory concentration: 22300 nM
The estimate for compound 3 lay 9.0-fold (0.95 log units) above the measured number; the measured number lies below the stated range.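

Within the amide side chain, the aryl group on the amide-type nitrogen clearly matters in this assay: 2-chloro-4-iodophenyl in place of 2-bromophenyl gives an at least 6.7-fold lower number from compound 2 to compound 3 (0.82 log units; beyond the scatter). Compound 2 stands only at a limit, so this step is a bound and not a size: the limit of > 150000 nM in this assay, at which 1 of the 3 values shown sits. With ((2-chloro-4-iodophenyl)carbamoyl)methyl in place of 4-fluorophenyl on the aromatic nitrogen, the change is a 3.1-fold higher number from compound 1 to compound 3 (0.48 log units; beyond the scatter), so the large step seen with compound 2 does not belong to the carbamoylmethyl link alone.

Compound 3 differs from compound 2 in both halogens at once, so the shares of the chlorine and the iodine cannot be separated. Going by these compounds, how a plain phenyl, a carboxylic acid on the aryl ring or a longer chain before the amide would read remains open.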